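This account rests on a few compounds, and the source may have more. Where it says the series, first, only, none or still open, it means among the compounds named here.

Of the compounds shown here, three that share one core have been measured in an ADME assay on microsomes from liver (Rattus norvegicus) for metabolic stability (on this read-out higher numbers stand for a longer-lived compound and lower numbers for a shorter-lived compound), and they differ only in the group on a saturated chain carbon bound to an aromatic carbon and a saturated chain carbon. Compound 1 `CC(C)C(Nc1nnc[nH]1)c1ccc(-c2ccc3cccc(F)c3c2)[nH]c1=O` gives 1.29 h and compound 2 `CC(C)C(Cc1nnn[nH]1)c1ccc(-c2ccc3cccc(F)c3c2)[nH]c1=O` gives 2.08 h on this scale. Compound 3 `CC(C)C(c1ccc(-c2ccc3cccc(F)c3c2)[nH]c1=O)N1CCNC1=O` gives 0.283 h as the lowest of the three numbers, clearly apart from both others.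

Compound 4 `CC(C)C(CC(N)=O)c1ccc(-c2ccc3cccc(F)c3c2)[nH]c1=O` differs from compound 3 in one place (carbamoylmethyl in place of 2-oxoimidazolidin-1-yl on a saturated chain carbon bound to an aromatic carbon and a saturated chain carbon), with carbamoylmethyl in place of 2-oxoimidazolidin-1-yl. Among the measured compounds shown here, two measured steps bear most directly on this change, as both arrive at the group that now leaves (a 4.6-fold lower number from compound 1 to compound 3 (0.66 log units; beyond the scatter); a 7.3-fold lower number from compound 2 to compound 3 (0.87 log units; beyond the scatter)). Both are modest but beyond the scatter, while the remaining step (a 1.6-fold higher number from compound 1 to compound 2 (0.21 log units; within the scatter)) stays within it. For the measured compounds named here, compound 2 (2.08 h) is the nearest guide, as its (1H-tetrazol-5-yl)methyl group also ends in a methyl link, although no measured compound carries carbamoylmethyl itself. A modest rise is therefore expected (a 3.5-fold higher number from compound 3 to compound 4 (0.55 log units; beyond the scatter)), of about the size of those two steps or somewhat smaller. Compound 4 is estimated at 1 h (expected range 0.4 h to 2.5 h).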

Compound 4, half-life: < 0.0667 h
Compound 4 ended at the assay's limit (the forecaster's own chance of this, stated with the estimate: 2%); middle value at least 14-fold (1.17 log units) from the limit.
By their numbers in this assay, from the lowest: compound 3; then compounds 1 and 2 (each within the scatter of the next). At a limit, below all of these: compound 4.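

In this assay, among the compounds shown here, compound 4 ends at a limit and not at a measured number: the limit of < 0.0667 h in this assay, at which 1 of the 4 values shown sits. Swapping 2-oxoimidazolidin-1-yl for carbamoylmethyl gives an at least 4.2-fold lower number from compound 3 to compound 4 (0.62 log units; beyond the scatter), so the lowest number among the earlier compounds was not the floor for this position, even though the entering and leaving groups have the same hydrogen-bond donor and acceptor counts. For the compounds shown here, the chain link shared by compound 2 and compound 4 does not hold the half-life either: carbamoyl in place of 1H-tetrazol-5-yl gives an at least 31-fold lower number from compound 2 to compound 4 (1.49 log units; beyond the scatter), and carbamoylmethyl in place of (4H-1,2,4-triazol-3-yl)amino gives an at least 19-fold lower number from compound 1 to compound 4 (1.28 log units; beyond the scatter), which shows that the group on this saturated chain carbon can shift the half-life far more than the earlier steps suggested.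

The compounds shown leave open whether this drop belongs to the terminal carbamoyl itself or to the open chain as a whole. A carboxylic acid, an N-methyl amide or a longer chain ending in carbamoyl at the same place would help separate those two readings.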